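Acetylation of the Oxime Oxygen: Expected Cytotoxicity of Compound 4

The source may hold more compounds than are shown below. What is called first, only, known or untested is meant among the compounds shown, and "the series" means these compounds.

Compound 1 `CCn1ccc2cc(C(=O)c3ccc(OC)c(OC)c3OC)ccc21` gives > 10000 nM in a functional assay on A549 cells (Homo sapiens) for cytotoxicity, read by XTT assay, with a stated time of 72 h (a higher number here means a weaker inhibitor, a lower number a stronger inhibitor), which is a limit of the assay.
Compound 2 `COc1ccc(/C(=N\O)c2ccc3c(ccn3C)c2)c(OC)c1OC` gives 1000 nM in this assay.
Compound 3 `CCn1ccc2cc(/C(=N/O)c3ccc(OC)c(OC)c3OC)ccc21` gives > 10000 nM in this assay, again a limit.

Among the compounds with values here, compound 2 therefore stands alone as the only measured number, while the other two sit at a limit (the limit of > 10000 nM in this assay, at which 2 of the 3 values shown sit). Compound 4 `COc1ccc(/C(=N\OC(C)=O)c2ccc3c(ccn3C)c2)c(OC)c1OC` differs from compound 2 by acetyl in place of hydrogen on an oxygen. Within the data shown here, the single measured step, an at least 10-fold higher number from compound 2 to compound 3 (1.00 log units; beyond the scatter), changes the chain on the aromatic nitrogen and leaves the oxime oxygen untouched, so no measured step bears on this acetylation. Compound 4 is expected to give 1500 nM in this assay, with a range from 400 nM to 6000 nM. The estimated step is a 1.5-fold higher number from compound 2 to compound 4 (0.18 log units; within the scatter), expected to remain within the scatter.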

Compound 4, half-maximal inhibitory concentration: > 10000 nM
Compound 4 ended at the assay's limit (the forecaster's own chance of this, stated with the estimate: 20%); middle value at least 6.6-fold (0.82 log units) away from the limit.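

In this assay, the oxime oxygen proves sensitive to change: acetyl in place of hydrogen there gives an at least 10-fold higher number from compound 2 to compound 4 (1.00 log units; beyond the scatter). Together with the chain on the aromatic nitrogen, this oxygen is now a second place where a single change from compound 2 loses its measured value. The value of compound 4 is a limit of the assay, shared with most of the compounds: the limit of > 10000 nM in this assay, at which 3 of the 4 values shown sit.

From the compounds shown here alone, it remains open whether a smaller methyl group on this oxygen would keep a measurable value. The same holds for a longer chain or a benzyl group there.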